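The source may hold more compounds than are shown below. What is called first, only, known or untested is meant among the compounds shown, and "the series" means these compounds.

Measured in a functional assay on MDA-MB-231 cells (Homo sapiens) for inhibition, read by CCK-8 assay, with a stated time of 48 h; a higher number here means a weaker inhibitor of growth, a lower number a stronger inhibitor of growth:
- compound 1 `Cc1ccccc1Nc1nc(Nc2ccc(N3CCN(C(=O)OC(C)(C)C)CC3)cc2)ncc1Cl`: 3260 nM
- compound 2 `CN1CCN(c2ccc(Nc3ncc(Cl)c(NCc4ccc(C(F)(F)F)cc4)n3)nc2)CC1`: 19100 nM

Compound 2 has the higher number of the two at 19100 nM, and its gap to compound 1 at 3260 nM lies beyond the scatter. Compound 3 `Cc1cccc(Nc2nc(Nc3ccc(N4CCN(C)CC4)cn3)ncc2Cl)c1` remains to be measured in this assay. It differs from compound 2 as follows: 3-methylphenyl in place of 4-(trifluoromethyl)benzyl on a nitrogen on an aromatic ring. That is, 3-methylphenyl stands in place of 4-(trifluoromethyl)benzyl on a nitrogen on an aromatic ring.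

Among the measured compounds shown here, no single-place step between measured compounds is available, so any expectation rests on thin ground. Compound 1, at 3260 nM, also bears a methylphenyl group on a nitrogen, though it differs from compound 3 elsewhere too. A move towards a lower number, beyond the scatter, is therefore expected, and the estimated step is a 3.8-fold lower number from compound 2 to compound 3 (0.58 log units; beyond the scatter). The expected value for compound 3 is 5000 nM, with an estimated range of 1500 nM to 15000 nM.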

Compound 3, concentration for 50% growth inhibition: 5270 nM
Compound 3: the middle estimate sits 1.1-fold (0.02 log units) below what was measured, within the range that was stated.
By their numbers in this assay, from the lowest: compounds 1 and 3 (each within the scatter of the next); then compound 2.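

In this assay, among the compounds shown here, 3-methylphenyl in place of 4-(trifluoromethyl)benzyl on a nitrogen on an aromatic ring gives a 3.6-fold lower number from compound 2 to compound 3 (0.56 log units; beyond the scatter) as the first single-place reading. Growth inhibition at this position thus depends on the group carried there, at least for this pair, where a group of 11 heavy atoms gives way to one of 7 and each keeps one six-membered aromatic ring of carbon only. The step alone cannot separate the loss of the benzyl carbon, the loss of the trifluoromethyl and the arrival of the methyl, and no measurement at hand gives a reason for it.

As far as these compounds go, whether an unsubstituted phenyl, a 3-methylbenzyl or a ring bearing an amine would read differently on this nitrogen stays open. Also open, from the compounds shown here alone, is whether the same step appears with other groups elsewhere on the shared core.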